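Reversing the hydroxypropyl-to-butyl change on the amide

The source may hold more compounds than are shown below. What is called first, only, known or untested is meant among the compounds shown, and "the series" means these compounds.

Compound 3 `N[C@H](CCO)C(=O)NCc1ccccc1` stands at a limit of the assay: in a functional assay on the whole organism (strain NMRI) with Mus musculus as the target, in the maximal electroshock model, with a stated time of 30 min (a lower number here means that less compound is needed, a higher number that more compound is needed for the effect), compound 3 gives > 160 mg/kg. Compound 1 `CCCC(N)C(=O)NCc1ccccc1` gives 39 mg/kg in this assay. Compound 2 `NCC(N)C(=O)NCc1ccccc1` gives only a limit in this assay, > 68 mg/kg. The step under consideration makes the change (1-aminobutyl in place of 1-amino-3-hydroxypropyl on a carbonyl carbon), yielding compound 4 `CCC[C@H](N)C(=O)NCc1ccccc1`. Among the measured compounds shown here, the one measured step that bears on it runs in the opposite direction: an at least 4.1-fold higher number from compound 1 to compound 3 (0.61 log units; beyond the scatter). Reversing that change should therefore lower the number, and the same sense appears in an at least 1.7-fold higher number from compound 1 to compound 2 (0.24 log units; that floor lies within the scatter), though only as a limit. Compound 4 is expected to give 30 mg/kg in this assay, with a range from 14 mg/kg to 70 mg/kg. That estimate means an at least 5.3-fold lower number from compound 3 to compound 4 (0.72 log units; beyond the scatter), so less compound is expected to be needed than for compound 3.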

Compound 4, dose for half-maximal effect: > 37 mg/kg
Compound 4: only a limit was reported; the forecaster's own chance of this, stated with the estimate: 10%; middle value at least 1.2-fold (0.09 log units) from the limit.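

In this assay compound 4 gives only a limit, > 37 mg/kg, and its steps from compound 1, compound 2 and compound 3 cannot be read. The compounds shown leave open whether 1-aminobutyl in place of 1-amino-3-hydroxypropyl lowers the number at all, and whether the defined configuration of compound 4 changes it relative to compound 1.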